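This account rests on a few compounds, and the source may have more. Where it says the series, first, only, none or still open, it means among the compounds named here.

Measured in a functional assay on LNCaP cells (Homo sapiens) for cytotoxicity, read by MTT assay; on this read-out higher numbers stand for weaker inhibition and lower numbers for stronger inhibition:
- Compound 1 `COc1ccc2cc([C@H](C)c3n[nH]c(=S)n3-c3cccc(Cl)c3)ccc2c1`: "not determined" (no result reported)
- Compound 2 `COc1ccc2cc([C@H](C)c3nnc(SCc4ccc(C)cc4)n3-c3ccc(F)cc3)ccc2c1`: <= 400000 nM, a limit and not a number
- Compound 3 `COc1ccc2cc([C@H](C)c3nnc(SCc4ccc(C)cc4)n3-c3ccc(Cl)cc3)ccc2c1`: 52200 nM

Compound 2 has no exact number, and its place on the scale is marked only by the limit of <= 400000 nM in this assay, at which 1 of the 3 values shown sits. Compound 1 gives no result, so it offers no comparison.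

Compound 4 `COc1ccc2cc([C@H](C)c3nnc(SCc4c(C)cc(C)cc4C)n3-c3ccc(F)cc3)ccc2c1` differs from compound 2 in one group: 2,4,6-trimethylphenyl in place of 4-methylphenyl on a saturated chain carbon bound to a sulfur. Put another way, 4-methylbenzyl becomes 2,4,6-trimethylbenzyl on the sulfur, and the rest of the molecule stays the same.

Going by the values given here, only one measured step exists, a step that the limit leaves unreadable from compound 2 to compound 3, and it swaps chloro for fluoro on an aromatic carbon. That is a different change from the one followed here, and its size cannot be read. Among the compounds with values here, no measured step therefore shows what the two added methyl-bearing positions of the new group do, and the data support no direction for the change.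

Within the data shown here, the one true number in this small series is that of compound 3, at 52200 nM, so the expectation leans on it and stays wide. The expected change is a step that the limit leaves unreadable from compound 2 to compound 4, an estimate with little behind it. Compound 4 is expected at 60000 nM, with an estimated range from 15000 nM to 240000 nM.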

Compound 4, half-maximal inhibitory concentration: 2210 nM
Beside the measured number, compound 4's estimate is 27-fold (1.43 log units) above it, and the stated range ends above it.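

In this assay, the step from compound 2 to compound 4 has no readable size, because compound 2 carries only a limit and not an exact number: the limit of <= 400000 nM in this assay, at which 1 of the 4 values shown sits.

The compounds shown leave open how much, and in which direction, 2,4,6-trimethylbenzyl in place of 4-methylbenzyl on the sulfur changes the cytotoxicity result.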